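Cyclohexyl in place of 5-cyanopentyl on an aromatic nitrogen

This account rests on a few compounds, and the source may have more. Where it says the series, first, only, none or still open, it means among the compounds named here.

Measured so far in a toxicity assay on HT-29 cells (Homo sapiens) for cytotoxicity; on this read-out lower numbers stand for higher toxicity in this test and higher numbers for lower toxicity in this test (each value is a limit):
- compound 1 (`CN1C(=S)[C@@H](NC(=O)c2nc(Cc3ccccc3)n(CCCF)n2)COc2ccccc21`) gives > 100000 nM 
- compound 2 (`COCCn1nc(C(=O)N[C@H]2COc3ccccc3N(C)C2=S)nc1Cc1ccccc1`) gives > 100000 nM 
- compound 3 (`CN1C(=S)[C@@H](NC(=O)c2nc(Cc3ccccc3)n(CCCCCC#N)n2)COc2ccccc21`) gives > 100000 nM 

Compound 3 stands at > 100000 nM in this assay as a limit and not a number, so it offers no exact starting point. The other two compounds give limits as well.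

Compound 4 (`CN1C(=S)[C@@H](NC(=O)c2nc(Cc3ccccc3)n(C3CCCCC3)n2)COc2ccccc21`) carries cyclohexyl in place of the 5-cyanopentyl of compound 3 on an aromatic nitrogen cyclohexyl in place of 5-cyanopentyl on an aromatic nitrogen and so has a ring where the three measured compounds have an open chain.

Among the measured compounds shown here, three measured steps bear on this change, all of them made on the chain at that nitrogen. They are a step that the two limits leave unreadable from compound 1 to compound 2 and a step that the two limits leave unreadable from compound 1 to compound 3 and a step that the two limits leave unreadable from compound 2 to compound 3 and none of them has a size that can be read. For the measured compounds named here, the only guide is the limit of > 100000 nM in this assay, at which 3 of the 3 values shown sit, and it offers no step to scale from.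

No step beyond the usual scatter is therefore expected, in either direction, and the estimate is a number no higher from compound 3 to compound 4 (the limit leaves the size open) in this assay with the limit again the likely report. The estimated value for compound 4 is 100000 nM with an expected range from 40000 nM to 200000 nM.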

Compound 4, half-maximal cytotoxic concentration: > 100000 nM
Compound 4 was reported as a limit; the forecaster's own chance of this, stated with the estimate: 85%; the middle value lies on the limit itself.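

In this assay compound 4 gives > 100000 nM, which is a limit and not a number. No step from compound 1, compound 2 or compound 3 to compound 4 can be read, because each pair has limits at both ends: the limit of > 100000 nM in this assay, at which 4 of the 4 values shown sit.

The compounds shown leave open whether any group on the aromatic nitrogen, open chain or cyclohexyl, changes the result in this assay.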